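Compound 3 to Compound 4: Phenyltriazolyl Replaces Phenylsulfonylamino

A few compounds are considered here, and "the series" means these few. Any claim that something is new, unique, unknown or untested is made for them only; others in the source may bear on it.

Compound 1 `COc1ccc(-c2c(C)nc3c(N4CC[C@@H](NC(=O)COc5ccccc5)C4)cc(C)nn23)cc1OC`. In an ADME assay on microsomes from liver (Homo sapiens) for metabolic stability, read by LC-MS, with NADPH named in the record, with a stated time of 60 min, tested at 1 uM, in the absence of a further agent (a lower number here means that less of the compound is left, a higher number that more of the compound is left), compound 1 gives > 95%, which is a limit of the assay and not a number.
Compound 2 `COc1ccc(-c2c(C)nc3c(N4CC[C@@H](NS(=O)(=O)C5CC5)C4)cc(C)nn23)cc1OC`. In this assay compound 2 gives > 95%, again a limit of the assay.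
Compound 3 `COc1ccc(-c2c(C)nc3c(N4CC[C@@H](NS(=O)(=O)c5ccccc5)C4)cc(C)nn23)cc1OC`. In this assay compound 3 gives > 95%, once more a limit of the assay.

Compound 3 therefore stands where every measured compound stands: at the limit of > 95% in this assay, at which 3 of the 3 values shown sit. The three single-point changes among them, a step that the two limits leave unreadable from compound 1 to compound 2, a step that the two limits leave unreadable from compound 1 to compound 3 and a step that the two limits leave unreadable from compound 2 to compound 3, all end at that limit, so none of them gives a readable size, and none shows any direction.

Compound 4 `COc1ccc(-c2c(C)nc3c(N4CC[C@@H](n5cc(-c6ccccc6)nn5)C4)cc(C)nn23)cc1OC` differs from compound 3 by 4-phenyl-1H-1,2,3-triazol-1-yl in place of (phenylsulfonyl)amino on a saturated ring carbon. Within the data shown here, no measured step involves a triazole, so none bears directly on this change, and the only guidance is that all three measured compounds, across an amide and two sulfonamides, sit at the limit. Compound 4 is therefore expected to remain high in this assay, with the step of a number at least 10 percentage points lower from compound 3 to compound 4 (that floor lies within the scatter) most likely too small to read, though a drop beyond the scatter cannot be excluded. Compound 4 is estimated at 85%, between 55% and 95%.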

Compound 4, percent of the compound remaining: "unstable" (no number reported)
Nothing numeric was reported for compound 4, and the estimate cannot be compared.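

In this assay compound 4 is recorded as "unstable" (no number reported), so no step can be read between compound 3 and compound 4. The compounds shown leave open how much of compound 4 remains, and so how large the change to 4-phenyl-1H-1,2,3-triazol-1-yl is.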